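From 4-methoxybenzyl to hexyl on a shared core

The compounds below may be only part of what the source reports. "The series", "measured", "known", "first", "only" and "open" are said of these compounds alone.

Measured in a functional assay on a cell-free system (Platelet, plasma, Homo sapiens) for inhibition, with stated times of 1 min and 3 min; a higher number here means a weaker inhibitor, a lower number a stronger inhibitor:
Compound 1 `CCCCCCNc1nc(SCC)nc2c1ncn2[C@@H]1O[C@H](CO)[C@@H](O)[C@H]1O`: "not determined" (no result reported)
Compound 2 `CCCSc1nc(NCc2ccc(OC)cc2)c2ncn([C@@H]3O[C@H](CO)[C@@H](O)[C@H]3O)c2n1`: 181000 nM

Only compound 2 has a number, so it cannot yet be ranked against anything. It stands alone at 181000 nM, while compound 1 has no result to compare with it. A single value gives a starting point but no trend.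

The next compound to be tested is compound 3 `CCCCCCNc1nc(SCCC)nc2c1ncn2[C@@H]1O[C@H](CO)[C@@H](O)[C@H]1O`. It differs from compound 2 in one place: pentyl in place of 4-methoxyphenyl on a saturated chain carbon bound to a nitrogen on an aromatic ring. In other words, (4-methoxybenzyl)amino becomes hexylamino.

For the measured compounds named here, no measured pair shows what a change of this kind does in this assay. Going by the values given here, the expected shift is therefore none beyond the scatter, with neither direction clearly favoured, and the only anchor is compound 2 at 181000 nM. The expected 1.2-fold lower number from compound 2 to compound 3 (0.08 log units; within the scatter) is small but uncertain. For compound 3 the estimated value is 150000 nM, with an expected range from 30000 nM to 600000 nM.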

Compound 3, half-maximal inhibitory concentration: 102000 nM
The estimate for compound 3 lay 1.5-fold (0.17 log units) above the measured number; the range from low to high includes it.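

The step of a 1.8-fold lower number from compound 2 to compound 3 (0.25 log units; within the scatter) lies within the usual scatter of this assay, so this first comparison at this position separates the two compounds by no measurable amount. Replacing 4-methoxyphenyl with pentyl, on a saturated chain carbon bound to a nitrogen on an aromatic ring, removes a six-membered aromatic ring and a hydrogen-bond acceptor and leaves fewer heavy atoms, yet the read-out shows no shift beyond that scatter. Nothing here gives a measured reason for this result, so it remains an observation about one pair of compounds.

Compound 1 has no number, so any step involving it cannot be read, and the single step shown cannot establish a trend for this position. Going by these compounds, it also remains open whether a group of another kind at the same place, such as a chain ending in an amine or a carboxylic acid, or a chain longer than hexyl, would move the number beyond the scatter.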